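Chloro Moved to Another Ring Carbon: Compound 4

A few compounds are considered here, and "the series" means these few. Any claim that something is new, unique, unknown or untested is made for them only; others in the source may bear on it.

Measured compounds and their values:
compound 1, `CN1C(=O)/C(=C(/S)N(C)c2ccccc2)C(=O)c2ccccc21`: 85%
compound 2, `CN1C(=O)/C(=C(/S)N(C)c2ccccc2)C(=O)c2cc(Cl)ccc21`: 100%
compound 3, `CN1C(=O)/C(=C(/S)N(C)c2ccccc2)C(=O)c2cc(Br)ccc21`: 98%

In a functional assay on the whole organism with Mus musculus as the target, at a dose of 32 mg/kg by the oral route (on this read-out lower numbers stand for less inhibition and higher numbers for more inhibition at the one dose given (going by the name of the read-out)), compound 1 gives 85%, the lowest of the three numbers; compound 3 stands nearest, compound 2 furthest, and both of those gaps lie beyond the usual scatter.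

Compound 4, `CN1C(=O)/C(=C(/S)N(C)c2ccccc2)C(=O)c2ccc(Cl)cc21`, has not yet been measured. Compared with compound 1 the change is chloro in place of hydrogen on an aromatic carbon. Within the data shown here, the chloro in compound 4 sits on a different aromatic carbon of the same ring than the chloro in compound 2, so no measured step matches it exactly. Among the measured compounds shown here, the steps that bear on it most are a number 15 percentage points higher from compound 1 to compound 2 (beyond the scatter) and a number 13 percentage points higher from compound 1 to compound 3 (beyond the scatter): a halogen on that ring raised the read-out modestly in both cases, and a number 2 percentage points lower from compound 2 to compound 3 (within the scatter) shows that chloro and bromo gave much the same result. A modest rise from compound 1 is therefore expected for compound 4, a number 8 percentage points higher from compound 1 to compound 4 (within the scatter), though with less certainty since the chloro sits elsewhere. Compound 4 is estimated to give 93%, within a range of 78% to 100%.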

Compound 4, a percentage reported as inhibition, in the whole organism at one dose (the size of the read-out at that dose, not a potency): -23%
Estimate against measurement, compound 4: 116 percentage points above, outside the stated range (below it).
By their numbers in this assay, from the lowest: compound 4; then compound 1; then compounds 3 and 2 (each within the scatter of the next).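

In this assay, chloro in place of hydrogen on this aromatic carbon, which is meta to a fused ring and para to a fused ring, gives a number 108 percentage points lower from compound 1 to compound 4 (beyond the scatter), while the same exchange on a different carbon of the same ring gave a number 15 percentage points higher from compound 1 to compound 2 (beyond the scatter). The result of this change therefore depends on which ring carbon carries the chloro, and here compound 4 gives -23%, a value below zero, so the inhibition seen with compound 1 is gone at this dose. Nothing available explains this reversal.

As far as these compounds go, it remains open whether bromo on this carbon would match chloro, as the two did on the other carbon in compound 2 and compound 3. Also open, from the compounds shown here alone, is whether a different group here, such as methoxy or an amine, would bring the same loss.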